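Halogen swap on the anilino ring of compound 1

The source may hold more compounds than are shown below. What is called first, only, known or untested is meant among the compounds shown, and "the series" means these compounds.

Compound 1 `O=C(/C=C/c1ccccc1)Nc1cc2ncnc(Nc3ccc(F)c(Cl)c3)c2s1` carries a (3-chloro-4-fluorophenyl)amino group on the shared core. In a functional assay on HeLa cells (Homo sapiens) for antiproliferative activity, read by MTT assay, with a stated time of 48 h (on this read-out higher numbers stand for weaker inhibition and lower numbers for stronger inhibition), compound 1 gives 2810 nM, the second highest of the three numbers in hand. Among the compounds with values here, compound 2 `COc1ccc(/C=C/C(=O)Nc2cc3ncnc(Nc4ccc(F)c(Cl)c4)c3s2)cc1` gives 20600 nM in this assay, and the single measured one-place step, a 7.3-fold higher number from compound 1 to compound 2 (0.87 log units; beyond the scatter), concerns methoxy in place of hydrogen on an aromatic carbon remote from the (3-chloro-4-fluorophenyl)amino group. Compound 3 `O=C(/C=C/c1ccccc1)Nc1cc2c(Nc3ccc(F)c(Cl)c3)ncnc2s1`, with a rearranged core, gives 2140 nM, within the scatter of compound 1.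

Compound 4 `O=C(/C=C/c1ccccc1)Nc1cc2ncnc(Nc3ccc(Cl)c(Cl)c3)c2s1` differs from compound 1 in one place: chloro in place of fluoro on an aromatic carbon, so that the (3-chloro-4-fluorophenyl)amino group becomes a (3,4-dichlorophenyl)amino group. Within the data shown here, no measured step touches this halogen position; the only step in hand sits elsewhere and was modest. The expectation for compound 4 in this assay is therefore a step of a 1.1-fold lower number from compound 1 to compound 4 (0.05 log units; within the scatter), that is, no change beyond the scatter. Compound 4 is estimated at 2500 nM, in the range 900 nM to 7000 nM.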

Compound 4, half-maximal inhibitory concentration: 10700 nM
Compound 4: middle estimate off by 4.3-fold (0.63 log units), on the low side; the measured number lies above the stated range.
By their numbers in this assay, from the lowest: compounds 3 and 1 (each within the scatter of the next); then compounds 4 and 2 (each within the scatter of the next).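

In this assay the step of a 3.8-fold higher number from compound 1 to compound 4 (0.58 log units; beyond the scatter) shows that this position responds to a single halogen exchange, with chloro in place of fluoro, ortho to a chloro group and para to a large group. Within the data shown here, the earlier compounds gave a measured step only at the remote aromatic carbon, so this is the first sign that the (3-chloro-4-fluorophenyl)amino group is not a silent part of the series, and here the change goes towards weaker inhibition. No measurement in hand accounts for the change.

As far as these compounds go, it remains open how hydrogen, bromo, methyl or methoxy would behave at this position. From the compounds shown here alone, it is also open whether the halogen step carries over to the core of compound 3 or to the methoxy-bearing compound 2.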